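Swapping the aryl group on the hydrazone carbon

This account rests on a few compounds, and the source may have more. Where it says the series, first, only, none or still open, it means among the compounds named here.

Of the compounds shown here, two with a shared core have been tested so far. Compound 2 `COc1cccc(/C=N/Nc2ncc3c(n2)n(C2CCCC2)c(=O)c(=O)n3C)c1` gives 20700 nM in a functional assay on PC-3 cells (Homo sapiens) for antiproliferative activity, read by MTT assay (a higher number here means a weaker inhibitor, a lower number a stronger inhibitor), the lowest of the two numbers. Compound 1 `Cn1c(=O)c(=O)n(C2CCCC2)c2nc(N/N=C/c3ccc(O)c(F)c3)ncc21` gives 85200 nM in this assay, and the change from compound 1 to compound 2 brought a 4.1-fold lower number from compound 1 to compound 2 (0.61 log units; beyond the scatter).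

Compound 3 `Cn1c(=O)c(=O)n(C2CCCC2)c2nc(N/N=C/c3ccc(C(F)(F)F)cc3)ncc21` is the next candidate. The change is 4-(trifluoromethyl)phenyl in place of 3-methoxyphenyl on a carbon with a double bond to nitrogen. Going by the values given here, only one measured step bears on it, the step from compound 1 to compound 2, which also swapped the aryl group on that same carbon and moved the number by a modest amount. That step points to the aryl group mattering, but it gives no direction for a trifluoromethyl group. The expected step from compound 2 to compound 3 is therefore a 1.1-fold higher number from compound 2 to compound 3 (0.03 log units; within the scatter), within the usual scatter. Compound 3 is expected to give 22000 nM, with a range from 6000 nM to 80000 nM.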

Compound 3, half-maximal inhibitory concentration: 23600 nM
Estimate against measurement, compound 3: 1.1-fold (0.03 log units) below; measured number inside the range.
By their numbers in this assay, from the lowest: compounds 2 and 3 (each within the scatter of the next); then compound 1.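

The aryl group on this carbon does not simply set the number by its size or by its substituent: 4-(trifluoromethyl)phenyl in place of 3-methoxyphenyl gives a 1.1-fold higher number from compound 2 to compound 3 (0.06 log units; within the scatter) in this assay even though the two groups share no substituent. A second replacement for 3-fluoro-4-hydroxyphenyl also gives a 3.6-fold lower number from compound 1 to compound 3 (0.56 log units; beyond the scatter) and so joins the first in leaving compound 1 with the highest number of the three, which shows that the earlier drop was not unique to 3-methoxyphenyl. Nothing available explains why these two groups match or why compound 1 stands apart.

Going by these compounds, it remains open whether any aryl group here can bring the number much lower. An amine or a carboxylic acid on the ring, or a plain alkyl chain in place of the ring, would test how much this position tolerates.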